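The compounds below may be only part of what the source reports. "The series", "measured", "known", "first", "only" and "open" are said of these compounds alone.

Measured so far in an ADME assay (liver) for metabolic stability, with Liver microsome (Homo sapiens) as the target, using microsomes and NADPH, with a stated time of 30 min, tested at 1 uM; a lower number here means slower removal, a higher number faster removal of the compound:
- compound 1, `Nc1ccc(S(=O)(=O)N2CCN(c3ncc(C(O)(C(F)(F)F)C(F)(F)F)cc3Br)CC2)cn1`: < 14 mL.min-1.g-1
- compound 2, `Cn1cc(-c2cc(C(O)(C(F)(F)F)C(F)(F)F)cnc2N2CCN(S(=O)(=O)c3ccc(N)nc3)CC2)cn1`: 19 mL.min-1.g-1
- compound 3, `CCn1cc(-c2cc(C(O)(C(F)(F)F)C(F)(F)F)cnc2N2CCN(S(=O)(=O)c3ccc(N)nc3)CC2)cn1`: 20 mL.min-1.g-1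

All three compounds share the core of compound 1 and differ only in the group on one aromatic carbon. The reading for compound 1, < 14 mL.min-1.g-1, is a limit of the assay rather than a number, so where compound 1 truly stands is known only as a range, and it is the one of the three that sits at this limit (the limit of < 14 mL.min-1.g-1 in this assay, at which 1 of the 3 values shown sits). Compound 2 gives 19 mL.min-1.g-1 and compound 3 gives 20 mL.min-1.g-1 in this assay.

Compound 4, `Nc1ccc(S(=O)(=O)N2CCN(c3ncc(C(O)(C(F)(F)F)C(F)(F)F)cc3-c3ccccc3O)CC2)cn1`, differs from compound 1 in one place: 2-hydroxyphenyl in place of bromo on an aromatic carbon. Within the data shown here, two measured steps bear on this, each also replacing bromo with an aromatic ring: an at least 1.3-fold higher number from compound 1 to compound 2 (0.13 log units; that floor lies within the scatter) and an at least 1.4-fold higher number from compound 1 to compound 3 (0.15 log units; that floor lies within the scatter). Both floors lie within the scatter, so the replacement of bromo by a ring has so far brought either no change beyond the scatter or a modest rise. The same is expected for compound 4: a small upward step at most, an at least 1.2-fold higher number from compound 1 to compound 4 (0.10 log units; that floor lies within the scatter). Compound 4 is therefore estimated at 18 mL.min-1.g-1, with a range from 8 mL.min-1.g-1 to 40 mL.min-1.g-1.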

Compound 4, intrinsic clearance in microsomes: 22 mL.min-1.g-1
Estimate against measurement, compound 4: 1.2-fold (0.09 log units) below; measured number inside the range.
By their numbers in this assay, from the lowest: compounds 2, 3 and 4 (each within the scatter of the next). At a limit, below all of these: compound 1.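

In this assay, a ring of carbon only that carries a hydroxyl, 2-hydroxyphenyl, cannot be told apart on this aromatic carbon from the nitrogen-containing rings 1-ethyl-1H-pyrazol-4-yl and 1-methyl-1H-pyrazol-4-yl: the readings give a 1.1-fold higher number from compound 3 to compound 4 (0.04 log units; within the scatter) and a 1.2-fold higher number from compound 2 to compound 4 (0.06 log units; within the scatter). So at this position, three different rings, one of them with a hydrogen-bond donor the other two lack, give numbers within the scatter of one another, and the kind of ring does not separate them in these compounds. Replacing bromo gives an at least 1.5-fold higher number from compound 1 to compound 4 (0.19 log units; that floor lies within the scatter), but the reading of compound 1 is a limit of the assay and not a number, so the true size of this step cannot be read: the limit of < 14 mL.min-1.g-1 in this assay, at which 1 of the 4 values shown sits.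

From the compounds shown here alone, how phenyl without the hydroxyl would compare with compound 4 remains open, so the part played by the hydroxyl on the ring cannot be separated from that of the ring itself. Also open, going by these compounds, is whether a group of a different kind on this carbon, such as an amine or a carboxylic acid, would move the number beyond the scatter.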